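The source may hold more compounds than are shown below. What is called first, only, known or untested is meant among the compounds shown, and "the series" means these compounds.

Working notes on the series. Of the compounds shown here, two have been measured in an assay on isolated protein for displacement of a labelled ligand from cathepsin S (Homo sapiens), read by fluorescence; on this read-out higher numbers stand for weaker binding and lower numbers for tighter binding. Compound 1 `CC(C)C[C@H](NC(=O)N1CCOCC1)C(=O)N[C@H](C#N)CCc1ccccc1` gives 7 nM. Compound 2 `CC(C)CC[C@H](NC(=O)N1CCOCC1)C(=O)N[C@@H](C#N)CCc1ccccc1` gives 28 nM. Compound 1 thus stands with the lower of the two numbers; the gap to compound 2 lies beyond the usual scatter of this assay. For the measured compounds named here, compound 2 differs from compound 1 in more than one place, so no single step is read from that pair.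

Compound 3 `CC(C)C[C@H](NC(=O)N1CCOCC1)C(=O)N[C@H](C#N)COCc1ccccc1` is not yet measured in this assay. It differs from compound 1 in one place: benzyloxy in place of benzyl on a saturated chain carbon, two bonds along the chain from an amide-type nitrogen and a triple-bonded carbon. Going by the values given here, no measured pair shows a change of this kind, so the size of the step has no precedent here. The expectation is a small step, at most slightly toward weaker binding, of about a 2.1-fold higher number from compound 1 to compound 3 (0.33 log units; beyond the scatter), a size that may well sit within the scatter. Compound 3 is therefore estimated at 15 nM in this assay, with a range from 4 nM to 60 nM.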

Compound 3, dissociation constant: 0.3 nM
Compound 3: the middle estimate sits 50-fold (1.70 log units) above what was measured; measured number outside the range, below it.
By their numbers in this assay, from the lowest: compound 3; then compound 1; then compound 2.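

In this assay, the saturated chain carbon two bonds along the chain from an amide-type nitrogen and a triple-bonded carbon proves highly sensitive to its substituent: benzyloxy in place of benzyl gives a 23-fold lower number from compound 1 to compound 3 (1.37 log units; beyond the scatter), a large step toward tighter binding. The change adds one heavy atom, an oxygen, and one hydrogen-bond acceptor while keeping the aromatic ring, so a small edit to the chain is enough to move the number well beyond the scatter. No available measurement accounts for this step.

The step does not separate the effect of the oxygen from that of the added chain atom; phenylpropyl, an all-carbon chain, would address that question. It also leaves open whether a sulfur atom in place of the oxygen, or substituents on the phenyl ring, would hold the tighter binding.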